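A few compounds are considered here, and "the series" means these few. Any claim that something is new, unique, unknown or untested is made for them only; others in the source may bear on it.

Measured in a functional assay on HCT-116 cells (Homo sapiens) for inhibition, read by MTT assay, with a stated time of 72 h; a higher number here means a weaker inhibitor, a lower number a stronger inhibitor:
compound 1 `COc1cc2c(Oc3ccc(NC(=O)c4nn(-c5ccccc5F)cc(C)c4=O)cc3F)ccnc2cc1OCCCCCC(=O)NO` gives 590 nM
compound 2 `COc1cc2c(Oc3ccc(NC(=O)c4nn(-c5ccccc5)cc(C)c4=O)cc3F)ccnc2cc1OCCCCCC(=O)NO` gives 690 nM
compound 3 `COc1cc2c(Oc3ccc(NC(=O)c4nn(-c5ccccc5F)cc(C)c4=O)cc3F)ccnc2cc1OCCCC(=O)NO` gives 1120 nM

Compound 4 `COc1cc2c(Oc3ccc(NC(=O)c4nn(-c5ccccc5F)cc(C)c4=O)cc3)ccnc2cc1OCCCC(=O)NO` is not yet measured. The change from compound 3 to compound 4 is hydrogen in place of fluoro on an aromatic carbon. The same kind of change has been made once already, from compound 1 to compound 2: hydrogen in place of fluoro on an aromatic carbon, where the step was a 1.2-fold higher number from compound 1 to compound 2 (0.07 log units; within the scatter). Around the place the two cases differ: in compound 1 the aromatic carbon is ortho to a large group only, while in compound 3 it is ortho to a large group and meta to a large group. The two cores differ by hydroxycarbamoyl in place of 2-(hydroxycarbamoyl)ethyl on a saturated chain carbon, three bonds along the chain from an oxygen on an aromatic ring, a step of a 1.9-fold higher number from compound 1 to compound 3 (0.28 log units; within the scatter). With a single precedent lying inside the scatter, the step expected from compound 3 to compound 4 is a 1.2-fold higher number from compound 3 to compound 4 (0.06 log units; within the scatter), resting on a 1.2-fold higher number from compound 1 to compound 2 (0.07 log units; within the scatter). Compound 4 is therefore estimated at 1300 nM, expected between 700 nM and 2500 nM.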

Compound 4, half-maximal inhibitory concentration: 950 nM
Compound 4: the middle estimate sits 1.4-fold (0.14 log units) above what was measured, and the stated range covers the measured number.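

In this assay, hydrogen in place of fluoro on an aromatic carbon gives a 1.2-fold lower number from compound 3 to compound 4 (0.07 log units; within the scatter), and the two cases of this change do not separate: the same change on two cores in this assay, a 1.2-fold higher number (0.07 log units; within the scatter) from compound 1 to compound 2 and a 1.2-fold lower number (0.07 log units; within the scatter) from compound 3 to compound 4, 1.4-fold (0.14 log units) apart, within the scatter of two such steps. On the core of compound 1 and the core of compound 3, the change therefore carries over with no step beyond the scatter. Both steps lie within the scatter, and two cases fix neither a direction nor a size for this change on any other core.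

Still open, going by these compounds, is whether chloro, methoxy or trifluoromethyl on that aromatic carbon would give a step beyond the scatter. Also open, on these data alone, is what a carboxylic acid in place of hydroxycarbamoyl, or a chain longer than that of compound 1, would give.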